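This account rests on a few compounds, and the source may have more. Where it says the series, first, only, none or still open, it means among the compounds named here.

Series notes. In a functional assay on CCRF-CEM cells (Homo sapiens), read by MTT assay, with a stated time of 72 h (on this read-out lower numbers stand for stronger inhibition and higher numbers for weaker inhibition), compound 1 `COc1ncnc2c1c(I)cn2[C@@H]1O[C@H](CO)[C@@H](O)[C@H]1O` gives 1150 nM. For compound 2 `Nc1nc2c(c(-c3ccccc3)cn2[C@@H]2O[C@H](CO)[C@@H](O)[C@H]2O)c(=O)[nH]1` the read-out in this assay is a limit of the assay, > 100000 nM, recorded as the limit of > 100000 nM in this assay, at which 1 of the 3 values shown sits. For compound 3 `Cc1nc(N)c2c(-c3ccsc3)cn([C@@H]3O[C@H](CO)[C@@H](O)[C@H]3O)c2n1` the read-out in this assay is likewise a limit, > 20000 nM, recorded as the limit of > 20000 nM in this assay, at which 1 of the 3 values shown sits. Compound 2 therefore stands at the weak end of the values shown, with no number of its own, only a limit. Compound 4 `Nc1nc2c(c(-c3ccco3)cn2[C@@H]2O[C@H](CO)[C@@H](O)[C@H]2O)c(=O)[nH]1` differs from compound 2 by furan-2-yl in place of phenyl on an aromatic carbon. No step between two measured compounds isolates such a change, so its size and direction in this assay cannot be read from the numbers shown; no step beyond the scatter is expected. Compound 4 is estimated at 100000 nM, within 30000 nM to 300000 nM. This estimate corresponds to an expected step of a number no higher from compound 2 to compound 4 (the limit leaves the size open).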

Compound 4, half-maximal inhibitory concentration: > 20000 nM
Compound 4 ended at the assay's limit; the forecaster's own chance of this, stated with the estimate: 75%; the middle value does not contradict the limit.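

Compound 2 stands at a limit (> 100000 nM). Among the compounds shown here, compound 4 also stands at a limit (> 20000 nM), so no step between the two can be read. The compounds shown leave open whether furan-2-yl in place of phenyl changes the read-out at all, and in which direction.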